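Ring contraction of the amide on a metabolically stable core

This account rests on a few compounds, and the source may have more. Where it says the series, first, only, none or still open, it means among the compounds named here.

Compound 1 `N#Cc1ccc(-c2cnc(N)c(-c3ccc(N)nc3)n2)cc1` gives > 90% in an ADME assay on microsomes from liver (Mus musculus) for metabolic stability, read by LC-MS, using NADPH, with a stated time of 30 min, tested at 0.1 uM, in the presence of a further agent that is not named here (on this read-out lower numbers stand for a less stable compound and higher numbers for a more stable compound), a limit of the assay rather than a number.
Compound 2 `Nc1ncc(-c2ccc(C(=O)O)cc2)nc1-c1ccc(C(F)(F)F)cc1` gives > 90% in this assay, again a limit.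
Compound 3 `Nc1ncc(-c2ccc(C(=O)N3CCC(O)CC3)cc2)nc1-c1ccc(C(F)(F)F)cc1` gives > 90% in this assay, also a limit.

Compound 3 therefore stands at the top edge of what this assay can report, and so do the two other measured compounds: the limit of > 90% in this assay, at which 3 of the 3 values shown sit. Among the compounds with values here, the only one-place step among them, a step that the two limits leave unreadable from compound 2 to compound 3, cannot be read, because both of its ends are limits.

Compound 4 `Nc1ncc(-c2ccc(C(=O)N3CC[C@H](O)C3)cc2)nc1-c1ccc(C(F)(F)F)cc1` is not yet measured. Its change from compound 3 is 3-hydroxypyrrolidin-1-yl in place of 4-hydroxypiperidin-1-yl on a carbonyl carbon. The measured steps give no sign that a change at this carbonyl carbon moves the read-out, but with every value a limit they cannot show a shift either. Compound 4 is expected to stay at the limit, so no step beyond the scatter is estimated: a step that the limit leaves unreadable from compound 3 to compound 4. The estimate for compound 4 in this assay is 93%, with a range from 80% to 100%.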

Compound 4, percent of the compound remaining: > 90%
Compound 4 was reported as a limit; the forecaster's own chance of this, stated with the estimate: 80%; the middle value does not contradict the limit.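

Compound 4 joins compound 2 and compound 3 at the top edge of the read-out, so neither step to compound 4 can be read: the limit of > 90% in this assay, at which 4 of the 4 values shown sit.

Whether 3-hydroxypyrrolidin-1-yl in place of 4-hydroxypiperidin-1-yl changes the stability of these compounds at all remains open.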